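The source may report more compounds than this note shows. Statements on the series, on what has been measured and on what is new or still open speak of the compounds shown alone.

Three compounds share a core that carries a (1-bromoethenyl)carbonyl group on a nitrogen on an aromatic ring, and they differ only in their methoxy groups. In a functional assay on FM3A cells (Mus musculus) for antiproliferative activity, with a stated time of 48 h (on this read-out higher numbers stand for weaker inhibition and lower numbers for stronger inhibition), compound 1 `C=C(Br)C(=O)Nc1ccc(C(=O)/C=C/c2ccccc2OC)cc1` gives 370 nM as its result. Compound 2 `C=C(Br)C(=O)Nc1ccc(C(=O)/C=C/c2cccc(OC)c2OC)cc1` gives 550 nM as its result, and compound 3 `C=C(Br)C(=O)Nc1ccc(C(=O)/C=C/c2ccc(OC)c(OC)c2OC)cc1` gives 530 nM as its result, so compound 2 stands level with both others within the usual scatter.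

Compound 4 `COc1cccc(/C=C/C(=O)c2ccc(N)cc2)c1OC` has not been measured yet. Its difference from compound 2 is this: hydrogen in place of (1-bromoethenyl)carbonyl on a nitrogen on an aromatic ring. In short, the whole group goes and the nitrogen keeps a plain hydrogen.

Two measured steps exist, a 1.5-fold higher number from compound 1 to compound 2 (0.17 log units; within the scatter) and a 1.0-fold lower number from compound 2 to compound 3 (0.02 log units; within the scatter), and both stay within the scatter. Each is a methoxy in place of hydrogen on an aromatic carbon, however, so neither tests the change at hand. Every measured compound keeps the group, which means the data hold no direct measure of losing it. This change is far bigger than a single methoxy swap, so a large move is expected rather than none. The expected step is a 22-fold higher number from compound 2 to compound 4 (1.34 log units; beyond the scatter) in this assay, toward a higher number and weaker inhibition, and this rests on judgement more than on a measured trend. For compound 4 the estimated value is 12000 nM with an expected range from 2500 nM to 50000 nM as its limits.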

Compound 4, half-maximal inhibitory concentration: 29000 nM
Compound 4: middle estimate off by 2.4-fold (0.38 log units), on the low side; measured number inside the range.
By their numbers in this assay, from the lowest: compounds 1, 3 and 2 (each within the scatter of the next); then compound 4.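

In this assay, going from ((1-bromoethenyl)carbonyl)amino to amino gives a 53-fold higher number from compound 2 to compound 4 (1.72 log units; beyond the scatter), so inhibition becomes much weaker once the group leaves the nitrogen. The methoxy swaps linking compound 1, compound 2 and compound 3 all stayed within the scatter, so those compounds gave no sign that any part of the structure strongly affects this read-out, whereas this step shows that what sits on this nitrogen matters a great deal. The data shown offer no explanation for the size of this loss.

Because the whole group leaves in one step, the result cannot show which part of it matters: the bromine, the carbon-carbon double bond, the carbonyl, or some combination of these, and an acetyl group or a propenoyl group without the bromine on the same nitrogen would help to separate these parts. For the compounds shown here, the loss is also seen only with the methoxy pattern of compound 2, so its size with the patterns of compound 1 or compound 3 remains open.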